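A few compounds are considered here, and "the series" means these few. Any claim that something is new, unique, unknown or untested is made for them only; others in the source may bear on it.

Compound 3 `CCCc1nc(-c2ccccc2)c(CNCCN2CCN(c3ccccc3F)CC2)o1` stands second of the three numbers in an assay on HEK293 cells for inhibition of Voltage-dependent T-type calcium channel subunit alpha-1G (Homo sapiens), read by fluorescence, tested at 10 uM (on this read-out higher numbers stand for more inhibition at the one concentration tested (going by the name of the read-out) and lower numbers for less inhibition), at 46.5%; compound 2 `CCCc1nc(-c2ccccc2)c(CNCCCN2CCN(c3ccccc3F)CC2)o1` gives 54.4%, within the scatter of it, and compound 1 `CCCc1nc(-c2ccccc2)c(CNCCCN2CCN(c3cccc(OC)c3)CC2)o1` gives 36.4%, beyond it. For the measured compounds named here, the one measured step, a number 18 percentage points higher from compound 1 to compound 2 (beyond the scatter), changes the whole aryl group on an amine nitrogen in a ring, not fluoro to trifluoromethyl. Compound 4 `CCCc1nc(-c2ccccc2)c(CNCCN2CCN(c3ccccc3C(F)(F)F)CC2)o1` differs from compound 3 by trifluoromethyl in place of fluoro on an aromatic carbon. Going by the values given here, no measured step bears directly on this exchange; the step from compound 1 to compound 2 shows only that a change at this aryl group can move the number modestly. Expected for compound 4 is therefore a step of a number 1.5 percentage points higher from compound 3 to compound 4 (within the scatter), none beyond the scatter. Compound 4 is estimated at 48%, with a range from 30% to 66%.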

Compound 4, a percentage reported as inhibition, at one concentration (the size of the read-out at that concentration, not a potency): 54.6%
The estimate for compound 4 lay 6.6 percentage points below the measured number; the range from low to high includes it.
By their numbers in this assay, from the lowest: compound 1; then compounds 3, 2 and 4 (each within the scatter of the next).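

In this assay the exchange on this aromatic carbon, ortho to a large group, gives a number 8.1 percentage points higher from compound 3 to compound 4 (within the scatter), so going from one heavy atom to four moves the number by no more than the scatter. The earlier step replaced the whole aryl group, whereas this one changes only the substituent. Nothing at hand bears on the reason for this result.

Open, as far as these compounds go, is how a nitrile, a methoxy group or an amine on this same carbon would read. Also open, from the compounds shown here alone, is whether the same exchange on compound 2 gives a like step.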